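A few compounds are considered here, and "the series" means these few. Any claim that something is new, unique, unknown or untested is made for them only; others in the source may bear on it.

Of the compounds shown here, three of this set have been tested in an ADME assay on MT4 cells (Homo sapiens) for activation, read by MTT assay (a higher number here means that more compound is tolerated, a lower number that less compound is tolerated), and a fourth remains to be measured. Compound 1 `CCCCSc1nc(C(C)c2c(F)cccc2Cl)cc(=O)[nH]1` carries a butyl group on a sulfur. In this assay compound 1 gives only a limit, > 73000 nM, not a number. Compound 2 `CC(c1cc(=O)[nH]c(SC2CCCC2)n1)c1c(F)cccc1Cl` differs from compound 1 by a single change: cyclopentyl in place of butyl on a sulfur. In this assay compound 2 likewise gives only a limit, > 71000 nM. Because both readings are limits, the step that the two limits leave unreadable from compound 1 to compound 2 cannot be given a size, as the entries the limit of > 73000 nM in this assay, at which 1 of the 3 values shown sits, and the limit of > 71000 nM in this assay, at which 1 of the 3 values shown sits, show.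

Compound 3 `CCCCSc1nc(C(C)c2c(F)cccc2F)c(CC)c(=O)[nH]1` has a different core; the difference between the two cores is not broken down here. In this assay compound 3 also gives only a limit, > 3000 nM, recorded as the limit of > 3000 nM in this assay, at which 1 of the 3 values shown sits.

Compound 4 `CCc1c(C(C)c2c(F)cccc2F)nc(SC2CCCC2)[nH]c1=O` has not been measured. It stands to compound 3 exactly as compound 2 stands to compound 1, by the same change at the same place: cyclopentyl in place of butyl on a sulfur. Because the earlier step that the two limits leave unreadable from compound 1 to compound 2 could not be read, no size carries over from it. What the data do show is that neither compound 1 nor compound 2 produced a number in this assay across the entries the limit of > 73000 nM in this assay, at which 1 of the 3 values shown sits, and (the limit of > 71000 nM in this assay, at which 1 of the 3 values shown sits). The step from compound 3 to compound 4 is therefore expected to be small, a step that the limit leaves unreadable from compound 3 to compound 4, with a limit rather than a number the most likely outcome. Compound 4 is estimated at 50000 nM, within a range from 10000 nM to 200000 nM.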

Compound 4, half-maximal cytotoxic concentration: > 3000 nM
Compound 4: a limit, no number (the forecaster's own chance of this, stated with the estimate: 85%); the middle value does not contradict the limit.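

In this assay compound 4 gives > 3000 nM as a limit and not a number. Compound 3 also gives only a limit, so no step can be read between compound 3 and compound 4. The compounds shown leave open how far the true value of each lies beyond its limit, and whether cyclopentyl in place of butyl on a sulfur changes the result at all.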